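The source may report more compounds than this note shows. Statements on the series, on what has been measured and on what is new or still open speak of the compounds shown alone.

Of the compounds shown here, three built on one shared core have been tested in a functional assay on T47D cells (Homo sapiens) for cytotoxicity, read by MTT assay, with a stated time of 2 days; a higher number here means a weaker inhibitor, a lower number a stronger inhibitor. Compound 1, `Cc1ccc2c(=O)[nH]c(-c3cccc(OC(F)(F)F)c3)nc2c1`, gives a reading reported only as a limit of the measurement, > 50000 nM. Compound 2, `Cc1ccc2nc(-c3cccc(OC(F)(F)F)c3)[nH]c(=O)c2c1`, likewise gives only a limit, > 50000 nM. Compound 3, `Cc1ccc2nc(-c3ccccc3C(F)(F)F)[nH]c(=O)c2c1`, also gives only a limit, > 50000 nM. Among the measured compounds shown here, compound 2 therefore stands exactly where every measured compound stands, at the limit of > 50000 nM in this assay, at which 3 of the 3 values shown sit; no compound has yet produced an actual number, and the three cannot be told apart from one another.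

Compound 4, `Cc1cccc(-c2nc3ccc(C)cc3c(=O)[nH]2)c1`, has not yet been measured. It differs from compound 2 in one place: methyl in place of trifluoromethoxy on an aromatic carbon. For the measured compounds named here, no step between two measured compounds is available to show what such an exchange does, so the only guide is that all three measured compounds sit at the same limit. On that basis the step expected is a step that the limit leaves unreadable from compound 2 to compound 4, meaning none beyond the usual scatter. Compound 4 is accordingly expected to give about 60000 nM in this assay, within a range from 20000 nM to 200000 nM, and most probably to be reported once more only as a limit rather than a number.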

Compound 4, half-maximal inhibitory concentration: > 50000 nM
Compound 4 ended at the assay's limit (the forecaster's own chance of this, stated with the estimate: 85%); the middle value is on the limit's open side.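

Compound 4 joins compound 2 at a limit of the measurement rather than an actual number, so no step can be read for methyl in place of trifluoromethoxy: the limit of > 50000 nM in this assay, at which 4 of the 4 values shown sit.

The compounds shown leave open whether any change to the shared core would give an actual number in this assay, and whether these four compounds differ at all.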